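The source may hold more compounds than are shown below. What is called first, only, known or untested is meant among the compounds shown, and "the series" means these compounds.

Measured so far in a functional assay on A549 cells (Homo sapiens) for antiproliferative activity, read by MTT assay, with a stated time of 48 h; on this read-out lower numbers stand for stronger inhibition and higher numbers for weaker inhibition:
compound 1 `COc1ccc(-c2cn3cc(C4=CCN(C(=O)C(C)(C)C)CC4)ccc3n2)cc1OC`: 4340 nM
compound 2 `COc1ccc(-c2cn3cc(C4=CCN(C(=O)c5ccccc5)CC4)ccc3n2)cc1OC`: 7700 nM

Compound 2 stands at the upper end of these two numbers, separated from compound 1 by a 1.8-fold higher number from compound 1 to compound 2 (0.25 log units; within the scatter), a gap that lies within the scatter. Compound 3 `COc1ccc(-c2cn3cc(C4=CCN(S(=O)(=O)c5ccccc5)CC4)ccc3n2)cc1OC` differs from compound 2 by phenylsulfonyl in place of benzoyl on an amine nitrogen in a ring. For the measured compounds named here, the only measured step, a 1.8-fold higher number from compound 1 to compound 2 (0.25 log units; within the scatter), changes the group on a carbonyl carbon and keeps the carbonyl itself, so it bears only loosely on this change; no measured step replaces a carbonyl with a sulfonyl. No step beyond the scatter is therefore expected in this assay. Compound 3 is estimated at 7000 nM (range 2500 nM to 20000 nM), an expected step of a 1.1-fold lower number from compound 2 to compound 3 (0.04 log units; within the scatter).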

Compound 3, half-maximal inhibitory concentration: 7660 nM
The estimate for compound 3 lay 1.1-fold (0.04 log units) below the measured number; the measured number falls inside the stated range.
By their numbers in this assay, from the lowest: compounds 1, 3 and 2 (each within the scatter of the next).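

In this assay, the amine nitrogen in the six-membered ring now carries a sulfonyl as well as a carbonyl, and phenylsulfonyl in place of benzoyl gives a 1.0-fold lower number from compound 2 to compound 3 (0.00 log units; within the scatter) with the rest of the molecule unchanged. Against the (tert-butyl)carbonyl group, phenylsulfonyl gives a 1.8-fold higher number from compound 1 to compound 3 (0.25 log units; within the scatter), so all three groups on this nitrogen lie within the scatter of one another. Nothing available explains this result. Still open, going by these compounds, is whether a small methyl group, a longer alkyl chain or a group carrying a carboxylic acid on this nitrogen would give a number beyond the scatter.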